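Adding a Second Trifluoromethyl Group: Compound 1 to Compound 4

The source may report more compounds than this note shows. Statements on the series, on what has been measured and on what is new or still open speak of the compounds shown alone.

Compound 1 `O=C(Nc1cccc(-n2cc(-c3ccncc3)c(-c3ccc(Cl)c(O)c3)n2)c1)Nc1cccc(C(F)(F)F)c1` gives 13700 nM in a functional assay on OVCAR-5 cells (Homo sapiens) for inhibition, read by sulforhodamine B assay, with a stated time of 48 h; on this read-out lower numbers stand for stronger inhibition of growth and higher numbers for weaker inhibition of growth.
Compound 2 `O=C(Nc1cccc(-n2cc(-c3ccncc3)c(-c3ccc(Cl)c(O)c3)n2)c1)Nc1ccc(Cl)c(Cl)c1` gives 2400 nM.
Compound 3 `COc1cc(-c2nn(-c3cccc(NC(=O)Nc4cccc(C(F)(F)F)c4)c3)cc2-c2ccncc2)ccc1Cl` gives 1270 nM.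

Among these three numbers compound 1 stands highest, that is, it is the weakest inhibitor of growth here. Its nearest neighbour is compound 2, reached by a 5.7-fold lower number from compound 1 to compound 2 (0.76 log units; beyond the scatter), and the furthest is compound 3, reached by an 11-fold lower number from compound 1 to compound 3 (1.03 log units; beyond the scatter).

The step now followed leads from compound 1 to compound 4 `O=C(Nc1cccc(-n2cc(-c3ccncc3)c(-c3ccc(Cl)c(O)c3)n2)c1)Nc1cc(C(F)(F)F)cc(C(F)(F)F)c1`. The change is trifluoromethyl in place of hydrogen on an aromatic carbon. Within the data shown here, only one measured step touches the same ring on the amide-type nitrogen: from compound 1 to compound 2, where a different pair of substituents on that ring lowered the number by a modest, clear amount. The step from compound 1 to compound 3 changes the oxygen on another ring and so says little about this position. A second trifluoromethyl group is therefore expected to lower the number by a modest amount, roughly a 2.7-fold lower number from compound 1 to compound 4 (0.44 log units; beyond the scatter). On that basis compound 4 is estimated at 5000 nM, expected to fall between 1500 nM and 15000 nM.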

Compound 4, concentration for 50% growth inhibition: 875 nM
Compound 4: the middle estimate sits 5.7-fold (0.76 log units) above what was measured; the whole stated range lies above it.
By their numbers in this assay, from the lowest: compounds 4, 3 and 2 (each within the scatter of the next, the first and the last beyond it); then compound 1.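

Placing a trifluoromethyl group on this aromatic carbon, meta to the trifluoromethyl group already present, gives a 16-fold lower number from compound 1 to compound 4 (1.19 log units; beyond the scatter) in this assay, so the position that holds only a hydrogen in compound 1 has a large influence on the growth read-out. The earlier step to compound 2 replaced the existing trifluoromethyl group with two chlorines, so it could not show what one added group does when the original group stays in place, whereas this step isolates that single addition. The compounds shown offer no measurement that accounts for this gain in growth inhibition.

As far as these compounds go, it remains open whether the effect is particular to trifluoromethyl or whether a chlorine, a methyl, a nitrile, an amine or a carboxylic acid on the same carbon would produce a comparable step. It is also unknown whether the second trifluoromethyl group would lower the number similarly on the core of compound 3, which carries a methyl on the oxygen in place of the hydrogen.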